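This account rests on a few compounds, and the source may have more. Where it says the series, first, only, none or still open, it means among the compounds named here.

Measured so far:
compound 1 `COc1nc2ccccc2n1C(=O)NCCCCc1ccccc1` — 13.9 nM
compound 2 `O=C(NCCCCc1ccccc1)N1C(=O)c2ccccc2C1=O` — 2.4 nM

In an assay on HEK293 cells for inhibition of acid ceramidase (Homo sapiens), read by fluorescence, with stated times of 30 min and 1 h (a higher number here means a weaker inhibitor, a lower number a stronger inhibitor), compound 1 gives 13.9 nM, the higher of the two numbers; compound 2 gives 2.4 nM, and the gap between the two lies beyond the scatter. These two differ in more than one place, so only the two values themselves can be compared.

Compound 3 `O=C(NCCCCc1ccccc1)n1cnc2ccccc21` has not been measured. Against compound 1 the change is hydrogen in place of methoxy on an aromatic carbon. For the measured compounds named here, no step between measured compounds of this kind is available, so the size and direction of the step from compound 1 to compound 3 rest on no precedent. The loss of the methoxy group is expected to cost some potency, with the step of a 1.8-fold higher number from compound 1 to compound 3 (0.25 log units; within the scatter) estimated as moderate and possibly not beyond the scatter. For compound 3 the expected value in this assay is 25 nM, with a range from 8 nM to 80 nM.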

Compound 3, half-maximal inhibitory concentration in the acid ceramidase assay: 2.5 nM
Beside the measured number, compound 3's estimate is 10-fold (1.00 log units) above it; the whole stated range lies above it.
By their numbers in the acid ceramidase assay, from the lowest: compounds 2 and 3 (each within the scatter of the next); then compound 1.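

In the acid ceramidase assay, hydrogen in place of methoxy on the aromatic carbon between two ring nitrogen atoms gives a 5.6-fold lower number from compound 1 to compound 3 (0.75 log units; beyond the scatter), so the methoxy group is not needed for potency on this core and its removal brings a gain. In a physicochemical assay for metabolic stability, read by HPLC, at pH 4.5, tested at 10 uM (on this read-out lower numbers stand for a shorter-lived compound and higher numbers for a longer-lived compound), compound 1 gives > 2 h, which is a limit of the assay. In the physicochemical assay, compound 3 gives > 2 h, again a limit.

The step between these two compounds on half-life cannot be read, as neither value is a number: the limit of > 2 h in the physicochemical assay, at which 2 of the 2 values shown sit. Still open, as far as these compounds go, are how an amine or a chlorine atom on this same carbon would compare with hydrogen in the acid ceramidase assay, and how far the half-life of either compound extends past the limit.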